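The source may report more compounds than this note shows. Statements on the series, on what has been measured and on what is new or still open speak of the compounds shown alone.

In an ADME assay on L1210/0 cells (Mus musculus) for cytotoxicity, with a stated time of 48 h (on this read-out lower numbers stand for stronger inhibition and higher numbers for weaker inhibition), compound 1 `Oc1ncnc2c1ncn2C[C@@H]1C[C@H](O)c2ccccc21` shows > 200000 nM, which is a limit of the assay and not a number. Compound 2 `O=C1O/C(=C\Cn2cc(Br)c(=O)[nH]c2=O)C(OCc2ccccc2)=C1OCc1ccccc1` gives 7500 nM, and compound 3 `O=C1O/C(=C\Cn2cc(Cl)c(=O)[nH]c2=O)C(OCc2ccccc2)=C1OCc1ccccc1` gives 12200 nM. Within the data shown here, compound 3 thus stands level with compound 2, the only other compound with a true number, since the swap of chloro for bromo gives a 1.6-fold higher number from compound 2 to compound 3 (0.21 log units; within the scatter).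

Compound 4 `O=C1O/C(=C\Cn2ccc(=O)[nH]c2=O)C(OCc2ccccc2)=C1OCc1ccccc1` has not yet been measured. Its structure departs from compound 3 at a single place, hydrogen in place of chloro on an aromatic carbon. Among the measured compounds shown here, the one measured step at this place is the swap between compound 2 and compound 3, and it stayed within the scatter. That step exchanged one halogen for another, whereas compound 4 has no halogen there, so it guides the expectation only loosely. A small move towards weaker inhibition is expected, but nothing clearly beyond the scatter. In this assay the expected change is a 1.2-fold higher number from compound 3 to compound 4 (0.09 log units; within the scatter). The estimated value for compound 4 is 15000 nM, with an expected range from 5500 nM to 42000 nM.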

Compound 4, half-maximal inhibitory concentration: 12900 nM
Compound 4: the middle estimate sits 1.2-fold (0.07 log units) above what was measured, within the range that was stated.
By their numbers in this assay, from the lowest: compounds 2, 3 and 4 (each within the scatter of the next). At a limit, above all of these: compound 1.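

In this assay, removing the halogen from this aromatic carbon altogether, rather than exchanging one halogen for another, gives a 1.1-fold higher number from compound 3 to compound 4 (0.02 log units; within the scatter), and the comparison with bromo gives a 1.7-fold higher number from compound 2 to compound 4 (0.24 log units; within the scatter). With hydrogen, chloro and bromo all within the scatter of one another, a halogen at this place is not required for the cytotoxicity seen with these three compounds. The data shown offer no measurement that explains this flat result.

The compounds shown say nothing about how an amine, a carboxylic acid or a longer chain at this place would behave, and any of these might move the number beyond the scatter. They also leave open which other parts of the shared core set the level of these numbers.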